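Dichlorothiophene replacement in a hydrazone series

This account rests on a few compounds, and the source may have more. Where it says the series, first, only, none or still open, it means among the compounds named here.

Three hydrazone compounds have been run in a functional assay on cells (Cancer cell lines, Homo sapiens) for inhibition; a lower number here means a stronger inhibitor of growth, a higher number a weaker inhibitor of growth. Compound 1 `N=C(N)N/N=C/c1c(-c2cccs2)nc2n1CCS2` gives 39800 nM in this assay, the highest number of the three. Compound 2 `Cc1cn2c(/C=N/Nc3ccccn3)c(-c3ccc(Cl)c([N+](=O)[O-])c3)nc2s1` gives 19500 nM in this assay, and compound 3 `Cc1cn2c(/C=N/NC(=N)N)c(-c3ccsc3)nc2s1` gives 19500 nM in this assay; each of these lies a step below compound 1 that falls beyond the usual scatter, while compound 2 and compound 3 give the same number as each other. Going by the values given here, no pair among the measured compounds differs in a single place, so no step can be read directly.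

Compound 4 `N=C(N)N/N=C/c1c(-c2cc(Cl)sc2Cl)nc2n1CCS2` is not yet measured. It differs from compound 1 in one place: 2,5-dichlorothiophen-3-yl in place of thiophen-2-yl on an aromatic carbon. Among the compounds with values here, with no matched step available, the expected size of the change from compound 1 is modest, most likely a small move toward a lower number, but a result within the scatter would not surprise. The number for compound 4 in this assay is estimated at 20000 nM with a range of 8000 nM to 60000 nM, which corresponds to an expected step of a 2.0-fold lower number from compound 1 to compound 4 (0.30 log units; within the scatter).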

Compound 4, concentration for total growth inhibition: 17400 nM
Beside the measured number, compound 4's estimate is 1.1-fold (0.06 log units) above it, within the range that was stated.
By their numbers in this assay, from the lowest: compounds 4, 2 and 3 (each within the scatter of the next); then compound 1.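

In this assay, going by these compounds alone, this position gives the first readable single-place step: 2,5-dichlorothiophen-3-yl in place of thiophen-2-yl gives a 2.3-fold lower number from compound 1 to compound 4 (0.36 log units; beyond the scatter). The step is modest, but it shows that the number responds to the group on this aromatic carbon of the core of compound 1, and that the larger dichlorinated thiophene does not raise it. No measurement available here accounts for the step.

The change alters both the chlorine substitution and the point of attachment of the thiophene, so the contribution of each remains unresolved. A 5-chlorothiophen-2-yl group would keep the attachment of compound 1 while adding chlorine, and an amine such as morpholine would test whether this position needs an aromatic ring at all.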